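Amidine thiosemicarbazides on breast cancer cells: pyridine swap

The source may hold more compounds than are shown below. What is called first, only, known or untested is meant among the compounds shown, and "the series" means these compounds.

Of the compounds shown here, three have been tested in a functional assay on MCF7 cells (Homo sapiens) for cytotoxicity, read by MTT assay, with a stated time of 72 h, tested at 3 uM; on this read-out higher numbers stand for more inhibition of growth at the one concentration tested and lower numbers for less inhibition of growth. Compound 1 `N/C(=N\NC(=S)N1CCOCC1)c1ccc(F)cn1` gives 33.9%. Compound 2 `N/C(=N\NC(=S)N1CCN(c2ccccn2)CC1)c1ccc(F)cn1` gives 27.1%. Compound 3 `Cc1cccc(/C(N)=N/NC(=S)N2CCCC2)n1` gives 26.6%. On these three numbers compound 2 lies between compound 1 and compound 3, and all three numbers sit within the usual scatter of one another, so no ranking among them can be drawn from this assay.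

Compound 4 `Cc1cccc(/C(N)=N/NC(=S)N2CCN(c3ccccn3)CC2)n1` has not yet been measured. It differs from compound 2 in one place: 6-methylpyridin-2-yl in place of 5-fluoropyridin-2-yl on a carbon with a double bond to nitrogen. Going by the values given here, no pair of measured compounds differs in this one place alone, so no measured step is available. What the data do show is that compound 3, which carries the same 6-methylpyridin-2-yl group as compound 4 on a different thiosemicarbazide end, and compound 1, which carries the 5-fluoropyridin-2-yl group of compound 2, both fall within the scatter of compound 2 in this assay.

The expected step is therefore a number 0.1 percentage points lower from compound 2 to compound 4 (within the scatter), none beyond the scatter in either direction. Compound 4 is estimated at 27% in this assay, with a range from 15% to 40%.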

Compound 4, percent growth inhibition at one concentration: 27.1%
The estimate for compound 4 lay 0.1 percentage points below the measured number, and the stated range covers the measured number.
By their numbers in this assay, from the lowest: compounds 3, 2, 4 and 1 (each within the scatter of the next).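

In this assay, going by these compounds alone, the exchange of 5-fluoropyridin-2-yl for 6-methylpyridin-2-yl on a carbon with a double bond to nitrogen gives no change at the digits printed from compound 2 to compound 4 (within the scatter), the first direct reading of this position with the thiosemicarbazide end held constant. Within the data shown here, earlier comparisons could only set compounds apart that also differed at that end, whereas this single pair shows that the two groups are not separated at the one concentration tested when that end is the one shared by compound 2 and compound 4. No measurement at hand bears on why the two groups read alike.

Going by these compounds, whether the same exchange reads alike on the morpholine or pyrrolidine ends of compound 1 and compound 3 remains open, and those two compounds differ from each other in more than one place, so they cannot settle it. Also open, on these data alone, is whether a phenyl group or an unsubstituted pyridin-2-yl on the same carbon would read alike, and whether a full concentration series would still fail to separate compound 2 and compound 4.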